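From a trifluoromethyl to two methyls on the aryl piperazine

The compounds below may be only part of what the source reports. "The series", "measured", "known", "first", "only" and "open" are said of these compounds alone.

Within the data shown here, in a functional assay on HL-60 cells (Homo sapiens) for inhibition, read by MTT assay, with a stated time of 72 h (a higher number here means a weaker inhibitor, a lower number a stronger inhibitor), compound 2 `Cc1nc(-c2ccccc2)c(C(=O)N2CCN(c3cccc(C(F)(F)F)c3)CC2)o1` gives 153 nM, the higher of the two numbers known here, while compound 1 `Cc1nc(-c2ccccc2)c(C(=O)N2CCN(c3cccc(C(N)=O)c3)CC2)o1` gives 71 nM, the sole measured step being a 2.2-fold higher number from compound 1 to compound 2 (0.33 log units; beyond the scatter). Compound 3 `Cc1nc(-c2ccccc2)c(C(=O)N2CCN(c3cccc(C)c3C)CC2)o1` differs from compound 2 by 2,3-dimethylphenyl in place of 3-(trifluoromethyl)phenyl on an amine nitrogen in a ring. Among the measured compounds shown here, no measured step touches a change of this kind, so the estimate leans on compound 2 alone and expects a step of a 1.0-fold lower number from compound 2 to compound 3 (0.01 log units; within the scatter) in this assay, no further than the scatter. Compound 3 is therefore estimated at 150 nM, within 40 nM to 600 nM.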

Compound 3, half-maximal inhibitory concentration: 35 nM
Compound 3: middle estimate off by 4.3-fold (0.63 log units), on the high side, outside the stated range (below it).
By their numbers in this assay, from the lowest: compound 3; then compound 1; then compound 2.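

At the amine nitrogen in the ring, the aryl group can shift the number further than the earlier pair showed: this assay records a 4.4-fold lower number from compound 2 to compound 3 (0.64 log units; beyond the scatter) and also a 2.0-fold lower number from compound 1 to compound 3 (0.31 log units; beyond the scatter), so compound 3, with its 2,3-dimethylphenyl, is the strongest of the three. A carbamoyl group is therefore not required for the lowest number seen here. No evidence given here explains this result. The compounds shown leave open whether both methyl groups are needed, and how a single methyl, a methoxy group or a chlorine on this aryl ring would compare.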